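A few compounds are considered here, and "the series" means these few. Any claim that something is new, unique, unknown or untested is made for them only; others in the source may bear on it.

Compound 1 `CN(C)CCn1cnnc1-c1cc(Oc2ccc(NC(=O)N/N=C/c3c(O)ccc4ccccc34)cc2F)ccn1`: 880 nM
Compound 2 `CN(C)CCn1cnnc1-c1cc(Oc2ccc(NC(=O)N/N=C/c3ccc(Cl)cc3)cc2F)ccn1`: 780 nM

In a functional assay on A549 cells (Homo sapiens) for cytotoxicity, read by MTT assay, with a stated time of 72 h (a lower number here means a stronger inhibitor, a higher number a weaker inhibitor), compound 2 at 780 nM stands level with compound 1, within the scatter of repeated measurements. Compound 3 `CN(C)CCn1cnnc1-c1cc(Oc2ccc(NC(=O)N/N=C/c3ccc(O)cc3O)cc2F)ccn1` differs from compound 2 as follows: 2,4-dihydroxyphenyl in place of 4-chlorophenyl on a carbon with a double bond to nitrogen. In words, it has 2,4-dihydroxyphenyl in place of 4-chlorophenyl on a carbon with a double bond to nitrogen. Among the measured compounds shown here, only one measured step bears on this place, a 1.1-fold lower number from compound 1 to compound 2 (0.05 log units; within the scatter), and it swapped two quite different groups without a change beyond the scatter. No shift beyond the scatter is therefore expected, and the estimated step is a 1.1-fold higher number from compound 2 to compound 3 (0.04 log units; within the scatter). The estimate for compound 3 is 850 nM, with an expected range from 300 nM to 2500 nM.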

Compound 3, half-maximal inhibitory concentration: 12700 nM
Estimate against measurement, compound 3: 15-fold (1.17 log units) below; the measured number lies above the stated range.
By their numbers in this assay, from the lowest: compounds 2 and 1 (each within the scatter of the next); then compound 3.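

The group on the carbon with a double bond to nitrogen does matter in this assay, since 2,4-dihydroxyphenyl brings a large weakening against 4-chlorophenyl (a 16-fold higher number from compound 2 to compound 3 (1.21 log units; beyond the scatter)). The step against 2-hydroxynaphthalen-1-yl is also large (a 14-fold higher number from compound 1 to compound 3 (1.16 log units; beyond the scatter)), so carrying a hydroxyl on this group does not alone separate compound 3 from compound 1. No measurement shown explains these steps. Still open, as far as these compounds go, is whether one hydroxyl of compound 3 accounts for the step or both are needed. A phenyl with a single hydroxyl, or methoxy groups in place of both hydroxyls, would address this.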